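Methoxy for methyl, tested on two different cores

The source may hold more compounds than are shown below. What is called first, only, known or untested is meant among the compounds shown, and "the series" means these compounds.

Compound 1 `Cc1cccc(C(=O)OC(CCN(C)C)c2ccc(Cl)cc2)c1C` and compound 2 `COc1cccc(C(=O)OC(CCN(C)C)c2ccc(Cl)cc2)c1C` share one core; compound 3 `Cc1cccc(C(=O)NC(CCN(C)C)c2ccc(Cl)cc2)c1C` and compound 4 `COc1cccc(C(=O)NC(CCN(C)C)c2ccc(Cl)cc2)c1C` share another. How the core of compound 3 differs from the core of compound 1 is not broken down here. In an assay on NIH3T3 cells with Urotensin-2 receptor (Homo sapiens) as the target (a lower number here means a smaller maximal response, a higher number a larger maximal response), compound 1 gives 91%, and compound 2 gives 88%. The step of a number 3 percentage points lower from compound 1 to compound 2 (within the scatter) goes with the change (methoxy in place of methyl on an aromatic carbon). In this assay compound 3 gives 159%, the highest of the three numbers, with compound 1 and compound 2 both lying beyond the scatter below it. Compound 4 carries the same change made on the core of compound 3: methoxy in place of methyl on an aromatic carbon. Because a number 3 percentage points lower from compound 1 to compound 2 (within the scatter) stayed within the scatter, a step of a number 4 percentage points lower from compound 3 to compound 4 (within the scatter) is expected; this rests on that single earlier case alone, and the second core has not been tested with this change before. Compound 4 is therefore estimated at 155% in this assay, with an expected range from 130% to 180%.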

Compound 4, largest response reached (reported as efficacy), in percent of the reference or control that the assay uses: 179%
For compound 4 the middle estimate is 24 percentage points below the measured one; low and high end bracket the measured number.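

In this assay, methoxy in place of methyl on an aromatic carbon goes with a number 20 percentage points higher from compound 3 to compound 4 (beyond the scatter). Set beside the earlier pair, the same change did not give the same step on the two cores: the same change on two cores in this assay, a number 3 percentage points lower (within the scatter) from compound 1 to compound 2 and a number 20 percentage points higher (beyond the scatter) from compound 3 to compound 4, 23 percentage points apart, beyond the scatter of two such steps. This shows that, in this series, a step read on the core of compound 1 cannot simply be carried over to the core of compound 3, but two pairs show neither what in the cores accounts for the gap nor how the change would run on any further core.

The compounds shown leave open how an ethyl, an ethoxy, a hydroxy or a chlorine on that same aromatic carbon would compare with methyl and methoxy on each of the two cores. They also leave open whether the gap between the two steps would persist with a longer chain or with a different amine in place of the dimethylamino group.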